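This account rests on a few compounds, and the source may have more. Where it says the series, first, only, none or still open, it means among the compounds named here.

Measured in a physicochemical assay for solubility, read by HPLC, using the shake flask method, measured as kinetic solubility, with a stated time of 2 h, at pH 7.4; a higher number here means a more soluble compound, a lower number a less soluble compound:
Compound 1 `Cc1ccc(-c2cnn3c(NCc4ccccn4)cc(C)nc23)cc1` gives < 5000 nM; this is a limit of the assay, not a number.
Compound 2 `Cc1cc(NCCCc2ccccn2)n2nc(C)c(-c3ccccc3)c2n1` gives 5900 nM.
Compound 3 `Cc1cc(NCc2c[nH]cn2)n2nc(C)c(-c3ccccc3)c2n1` gives 14600 nM.

Compound 1 thus stands at the limit of this assay, a point at which, as the evidence shows, one of the three values sits (the limit of < 5000 nM in this assay, at which 1 of the 3 values shown sits). Compound 4 `Cc1cc(NCc2ccccn2)n2ncc(-c3c(C)cccc3C)c2n1` differs from compound 1 at a single place: 2,6-dimethylphenyl in place of 4-methylphenyl on an aromatic carbon.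

Among the measured compounds shown here, only one measured step within this set is available, a 2.5-fold higher number from compound 2 to compound 3 (0.39 log units; beyond the scatter), and it concerns an exchange of a group on a saturated chain carbon bound to a nitrogen on an aromatic ring, not a change on the aromatic carbon of the fused five-membered ring that separates compound 1 from compound 4. It therefore gives no direct guide to the step at hand. For the measured compounds named here, with no measured step bearing on this change, compound 4 is expected to show no shift beyond the scatter, so that a step that the limit leaves unreadable from compound 1 to compound 4 is the estimated step. Compound 4 is estimated at 3000 nM, within a range from 1000 nM to 8000 nM, with a fair chance that this assay again reports only a limit for compound 4.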

Compound 4, solubility: < 5000 nM
Compound 4 ended at the assay's limit; the forecaster's own chance of this, stated with the estimate: 55%; the middle value lies beyond the limit too.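

Compound 1 and compound 4 both give only a limit in this assay, not a number, so no step between them can be read: the limit of < 5000 nM in this assay, at which 2 of the 4 values shown sit.

The compounds shown leave open whether 2,6-dimethylphenyl in place of 4-methylphenyl on an aromatic carbon changes the solubility read-out at all.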